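The compounds below may be only part of what the source reports. "The series", "measured", "known", "first", "only" and "open" are said of these compounds alone.

Of the compounds shown here, three built on one shared core have been measured in an assay on membranes from Sf9 cells for displacement of a labelled ligand from histamine H2 receptor (Homo sapiens), read by scintillation counting, with a stated time of 60 min; on this read-out higher numbers stand for weaker inhibition and lower numbers for stronger inhibition. Compound 1 `CCCNC(=O)/N=C(\N)NCCCc1sc(N)nc1C` gives 105 nM in this assay. Compound 2 `Cc1nc(N)sc1CCCN/C(N)=N/C(=O)NC(c1ccccc1)c1ccccc1` gives 43.7 nM there, and compound 3 `Cc1nc(N)sc1CCCN/C(N)=N/C(=O)NCc1ccccc1` gives 69.2 nM. On these numbers compound 3 stands second highest of the three, yet the step of a 1.5-fold lower number from compound 1 to compound 3 (0.18 log units; within the scatter) and the step of a 1.6-fold higher number from compound 2 to compound 3 (0.20 log units; within the scatter) both lie within the scatter, so the three are not separated beyond it.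

Compound 4 `CCC(NC(=O)/N=C(\N)NCCCc1sc(N)nc1C)c1ccccc1` differs from compound 3 in one place: ethyl in place of hydrogen on a saturated chain carbon bound to an amide-type nitrogen and an aromatic carbon. For the measured compounds named here, no measured pair shows this exact change. The closest guide is a 1.6-fold higher number from compound 2 to compound 3 (0.20 log units; within the scatter), where a group on the same carbon was taken away with a step inside the scatter, and a 1.5-fold lower number from compound 1 to compound 3 (0.18 log units; within the scatter), likewise inside the scatter. Compound 4 is therefore expected to show only a small step, a 1.4-fold lower number from compound 3 to compound 4 (0.14 log units; within the scatter), in this assay. Compound 4 is expected to give about 50 nM in this assay, with a range from 20 nM to 130 nM.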

Compound 4, inhibition constant: 63.1 nM
The estimate for compound 4 lay 1.3-fold (0.10 log units) below the measured number, and the stated range covers the measured number.
By their numbers in this assay, from the lowest: compounds 2, 4, 3 and 1 (each within the scatter of the next, the first and the last beyond it).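

In this assay, ethyl on the saturated chain carbon bound to an amide-type nitrogen and an aromatic carbon stays within the scatter, with a 1.1-fold lower number from compound 3 to compound 4 (0.04 log units; within the scatter), and ethyl in place of phenyl at that carbon does too, with a 1.4-fold higher number from compound 2 to compound 4 (0.16 log units; within the scatter). Phenyl in place of hydrogen on the saturated chain carbon bound to an amide-type nitrogen and a saturated chain carbon also stays within the scatter, with a 1.7-fold lower number from compound 1 to compound 4 (0.22 log units; within the scatter), so hydrogen, ethyl and phenyl have now all been read at this carbon without a single-place step leaving it. Phenyl in place of ethyl now reads alike whether the carbon also carries hydrogen or phenyl: the same change on two cores in this assay, a 1.5-fold lower number (0.18 log units; within the scatter) from compound 1 to compound 3 and a 1.4-fold lower number (0.16 log units; within the scatter) from compound 4 to compound 2, 1.1-fold (0.02 log units) apart, within the scatter of two such steps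

The groups shown at this carbon are only hydrogen, ethyl and phenyl. On these data alone, how an amine, a carboxylic acid or a hydroxyl there would read in this assay stays open.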